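A few compounds are considered here, and "the series" means these few. Any claim that something is new, unique, unknown or untested is made for them only; others in the source may bear on it.

Measured in a functional assay on HepG2 cells (Homo sapiens) for cytotoxicity, read by MTT assay, with a stated time of 72 h; on this read-out higher numbers stand for weaker inhibition of growth and lower numbers for stronger inhibition of growth:
compound 1 `CS/C(=N\C(=O)c1csc([N+](=O)[O-])c1)NC(=O)c1csc([N+](=O)[O-])c1` gives a limit, > 100000 nM.
compound 2 `O=C(/N=C(/NC(=O)c1cccs1)[Se]Cc1ccccc1)c1cccs1` gives 58100 nM.
compound 3 `CS/C(=N\C(=O)c1cccs1)NC(=O)c1cccs1` gives a limit, > 100000 nM.

Compound 2 and compound 3 differ in one place: a group of 8 heavy atoms (7 carbon, 1 selenium; one six-membered aromatic ring of carbon only) in place of a group of 2 heavy atoms (1 carbon, 1 sulfur; no ring), on a carbon with a double bond to nitrogen. That change gave an at least 1.7-fold lower number from compound 3 to compound 2 (0.23 log units; that floor lies within the scatter). How the core of compound 1 differs from the core of compound 3 is not broken down here. Compound 4 `O=C(/N=C(/NC(=O)c1csc([N+](=O)[O-])c1)[Se]Cc1ccccc1)c1csc([N+](=O)[O-])c1` is not yet measured; it differs from compound 1 by a group of 8 heavy atoms (7 carbon, 1 selenium; one six-membered aromatic ring of carbon only) in place of a group of 2 heavy atoms (1 carbon, 1 sulfur; no ring), on a carbon with a double bond to nitrogen, the same change at the same place. Compound 1 stands at a limit in this assay, and the measured step in this assay also started from a limit, as the limit of > 100000 nM in this assay, at which 2 of the 3 values shown sit, shows. For compound 4 a step like the earlier one is expected, an at least 1.4-fold lower number from compound 1 to compound 4 (0.15 log units; that floor lies within the scatter), resting on an at least 1.7-fold lower number from compound 3 to compound 2 (0.23 log units; that floor lies within the scatter). Compound 4 is therefore estimated at 70000 nM, between 25000 nM and 150000 nM.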

Compound 4, concentration for total growth inhibition: 62800 nM
The estimate for compound 4 lay 1.1-fold (0.05 log units) above the measured number; the range from low to high includes it.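

In this assay, putting the group of 8 heavy atoms with its selenium and six-membered aromatic ring in place of methylsulfanyl, on the carbon with a double bond to nitrogen, gave an at least 1.5-fold lower number from compound 1 to compound 4 (0.20 log units; that floor lies within the scatter). Set beside the earlier step, this shows the change giving a measurable number on both cores, but not whether its size is the same: the same change on two cores in this assay, an at least 1.7-fold lower number (0.23 log units; that floor lies within the scatter) from compound 3 to compound 2 and an at least 1.5-fold lower number (0.20 log units; that floor lies within the scatter) from compound 1 to compound 4; the limit leaves it open whether they differ. Both steps start from a limit, so neither size is known and neither floor clears the scatter: the limit of > 100000 nM in this assay, at which 2 of the 4 values shown sit.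

The compounds shown leave open what the same group with sulfur in place of selenium would give on either core. From the compounds shown here alone, an amine or a longer chain on that carbon also remains open, so the contributions of the selenium and the aromatic ring cannot be separated.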